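The source may report more compounds than this note shows. Statements on the series, on what has been measured and on what is new or still open speak of the compounds shown alone.

Compounds measured so far:
compound 1 `c1ccc2c(c1)CN[C@@H](CN(CC1CCNCC1)[C@H]1CCCc3cccnc31)C2` — 86%
compound 2 `c1ccc2c(c1)CN[C@@H](CN(CC[C@@H]1CCCNC1)[C@H]1CCCc3cccnc31)C2` — 75%

In an ADME assay on microsomes from liver (Homo sapiens) for metabolic stability, read by LC-MS, with a stated time of 10 min, tested at 0.5 uM (on this read-out lower numbers stand for a less stable compound and higher numbers for a more stable compound), compound 1 gives 86%, while compound 2 gives 75%. Going by the values given here, compound 2 therefore stands lowest of the two numbers, and the one measured step, a number 11 percentage points lower from compound 1 to compound 2 (beyond the scatter), is a modest loss of stability that came with (piperidin-3-yl)methyl in place of piperidin-4-yl on a saturated chain carbon bound to an amine nitrogen.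

Compound 3 `CC(C)N1CCN(CCCN(C[C@H]2Cc3ccccc3CN2)[C@H]2CCCc3cccnc32)CC1` has not yet been tested in this assay. It differs from compound 2 by (4-isopropylpiperazin-1-yl)methyl in place of piperidin-3-yl on a saturated chain carbon, two bonds along the chain from an amine nitrogen. Among the compounds with values here, the only step that bears on this change is the one from compound 1 to compound 2, since it touches the same part of the shared core, and that step was modest. Within the data shown here, with the single comparison at hand, the direction of the new step is uncertain, but a further small loss, or no step beyond the scatter, seems the most likely outcome.

The estimated step is a number 10 percentage points lower from compound 2 to compound 3 (within the scatter). Compound 3 is thus expected to give 65% in this assay, with a range from 45% to 85%.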

Compound 3, percent of the compound remaining: 46%
Compound 3: middle estimate off by 19 percentage points, on the high side, within the range that was stated.
By their numbers in this assay, from the lowest: compound 3; then compound 2; then compound 1.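

In this assay, going by these compounds alone, this position on a saturated chain carbon proved far less forgiving than the one earlier step suggested: 2-(4-isopropylpiperazin-1-yl)ethyl in place of piperidin-4-yl gives a number 40 percentage points lower from compound 1 to compound 3 (beyond the scatter), the first large step in this small set. Against the closer neighbour, (4-isopropylpiperazin-1-yl)methyl in place of piperidin-3-yl gives a number 29 percentage points lower from compound 2 to compound 3 (beyond the scatter), so the two swaps of the terminal group both lower the number beyond the scatter, and the new group, with its six-membered ring holding two hetero atoms and no hydrogen-bond donor, sits lowest of the three. Nothing available explains why the number falls with this change.

The change swaps the ring, adds the isopropyl group and alters the chain all at once, so the compounds shown do not say which of these parts goes with the loss. Going by these compounds, a 2-(piperidin-4-yl)ethyl group, or a 2-(piperazin-1-yl)ethyl group without the isopropyl, would separate the chain from the ring and from the isopropyl group, and that separation remains open.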